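The compounds below may be only part of what the source reports. "The series", "measured", "known", "first", "only" and "open" are said of these compounds alone.

Measured so far in an ADME assay on L132 cells (Homo sapiens) for cytotoxicity, read by MTT assay, with a stated time of 48 h; a higher number here means a weaker inhibitor, a lower number a stronger inhibitor:
- compound 1 `C/C(=C\CC/C(C)=C/CC[C@@H]1[C@@]2(C)CCC(=O)C(C)(C)[C@H]2CC[C@@]1(C)O)CC/C=C(\C)C(=O)OCc1cn(-c2cccc(O)c2)nn1`: 146000 nM
- compound 2 `C/C(=C\CC/C(C)=C/CC[C@@H]1[C@@]2(C)CCC(=O)C(C)(C)[C@H]2CC[C@@]1(C)O)CC/C=C(\C)C(=O)OCc1cn(-c2ccccc2C(F)(F)F)nn1`: > 150000 nM
- compound 3 `C/C(=C\CC/C(C)=C/CC[C@@H]1[C@@]2(C)CCC(=O)C(C)(C)[C@H]2CC[C@@]1(C)O)CC/C=C(\C)C(=O)OCc1cn(-c2ccc(F)cc2)nn1`: > 150000 nM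

Going by the values given here, compound 1 holds the only number here; in this assay it gives 146000 nM. Compound 2 gives only a limit of this assay, > 150000 nM. Compound 3 likewise gives only a limit, > 150000 nM. Both sit at the limit of > 150000 nM in this assay, at which 2 of the 3 values shown sit.

Compound 4 `C/C(=C\CC/C(C)=C/CC[C@@H]1[C@@]2(C)CCC(=O)C(C)(C)[C@H]2CC[C@@]1(C)O)CC/C=C(\C)C(=O)OCc1cn(-c2ccc(Cl)cc2)nn1` differs from compound 1 by 4-chlorophenyl in place of 3-hydroxyphenyl on an aromatic nitrogen. The two steps that bear on it, an at least 1.0-fold higher number from compound 1 to compound 2 (0.01 log units; that floor lies within the scatter) and an at least 1.0-fold higher number from compound 1 to compound 3 (0.01 log units; that floor lies within the scatter), are both floored by the limit, so their true size is not known. The nearest analogue, compound 3 with 4-fluorophenyl, sits at the limit, and compound 4 is expected to do the same or nearly so; the expected step is a 1.1-fold higher number from compound 1 to compound 4 (0.04 log units; within the scatter). The estimate for compound 4 in this assay is 160000 nM, within 100000 nM to 300000 nM.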

Compound 4, half-maximal inhibitory concentration: > 150000 nM
Compound 4: a limit, no number (the forecaster's own chance of this, stated with the estimate: 70%); the middle value is on the limit's open side.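

In this assay compound 4 returns a limit and not a number. The change on the aromatic nitrogen gives an at least 1.0-fold higher number from compound 1 to compound 4 (0.01 log units; that floor lies within the scatter), so 4-chlorophenyl, like 4-fluorophenyl and 2-(trifluoromethyl)phenyl, shows no readable separation from 3-hydroxyphenyl, and the steps linking compound 4 to compound 2 and compound 3 cannot be read. Changes to the aryl group at this position now mostly end at one value: the limit of > 150000 nM in this assay, at which 3 of the 4 values shown sit.

From the compounds shown here alone, whether the true values of compound 2, compound 3 and compound 4 differ remains open. Also open, going by these compounds, is whether an amine or a carboxylic acid in place of the chloro group gives a number rather than a limit.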